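The source may report more compounds than this note shows. Statements on the series, on what has been measured and on what is new or still open speak of the compounds shown alone.

Measured in an ADME assay on the whole organism (Mus musculus, strain CD-1) for pharmacokinetics; a lower number here means slower removal, a higher number faster removal of the compound:
- compound 1 `COc1cc([C@](O)(CCN(C)C)[C@@H](c2cc3cc(Br)ccc3nc2OC)c2ccnc(OC)c2OC)cc(OC(C)C)n1` gives 6.8 mL/min/kg
- compound 2 `CCCOc1cc([C@](O)(CCN(C)C)[C@@H](c2cc3cc(Br)ccc3nc2OC)c2ccnc(OC)c2OC)cc(OC)n1` gives 6.9 mL/min/kg
- compound 3 `COc1cc([C@](O)(CCN(C)C)[C@@H](c2cc3cc(Br)ccc3nc2OC)c2ccnc(OC)c2OC)cc(OC2CCC2)n1` gives 11 mL/min/kg

Compound 2 stands among these three without separating from either of the others. On one side lies a 1.0-fold higher number from compound 1 to compound 2 (0.01 log units; within the scatter), and on the other lies a 1.6-fold higher number from compound 2 to compound 3 (0.20 log units; within the scatter).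

The unmeasured compound 4 `COc1nc2ccc(Br)cc2cc1[C@@H](c1ccnc(OC)c1OC)[C@@](O)(CCN(C)C)c1cc(SC)nc(SC)c1` departs from compound 2 in one place, on a saturated chain carbon bound to an oxygen on a saturated carbon and two saturated chain carbons. The change there is a group of 10 heavy atoms (7 carbon, 1 nitrogen, 2 sulfur; one six-membered aromatic ring with 1 hetero atom) in place of a group of 12 heavy atoms (9 carbon, 1 nitrogen, 2 oxygen; one six-membered aromatic ring with 1 hetero atom), on a saturated chain carbon bound to an oxygen on a saturated carbon and two saturated chain carbons.

The closest evidence comes from exchanges of the group on an oxygen on an aromatic ring, which gave a 1.0-fold higher number from compound 1 to compound 2 (0.01 log units; within the scatter), a 1.6-fold higher number from compound 1 to compound 3 (0.21 log units; within the scatter) and a 1.6-fold higher number from compound 2 to compound 3 (0.20 log units; within the scatter). All three stayed within the scatter. None of them, however, replaces oxygen with sulfur, so the measured series offers only indirect guidance for this wider exchange.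

A modest step is therefore expected, leaning slightly towards faster removal and not clearly beyond the scatter. The expected change is a 1.4-fold higher number from compound 2 to compound 4 (0.16 log units; within the scatter).

For compound 4 the estimated clearance is 10 mL/min/kg, with an expected range from 5 mL/min/kg to 20 mL/min/kg.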

Compound 4, clearance: 18 mL/min/kg
For compound 4 the middle estimate is 1.8-fold (0.26 log units) below the measured one; the measured number falls inside the stated range.
By their numbers in this assay, from the lowest: compounds 1, 2, 3 and 4 (each within the scatter of the next, the first and the last beyond it).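

In this assay, going by these compounds alone, the place on a saturated chain carbon bound to an oxygen on a saturated carbon and two saturated chain carbons gives the first steps that lie beyond the scatter: a 2.6-fold higher number from compound 2 to compound 4 (0.42 log units; beyond the scatter) and a 2.6-fold higher number from compound 1 to compound 4 (0.42 log units; beyond the scatter). Exchanges of the group on an oxygen on an aromatic ring had kept compound 1, compound 2 and compound 3 within the scatter of one another, whereas the wider exchange, which brings in a group of 10 heavy atoms with 2 sulfur in place of a group of 12 heavy atoms with 2 oxygen, shows that removal at this place can become clearly faster. The two groups have the same counts of hydrogen-bond donors and acceptors and no net charge, and nothing measured here accounts for the step.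

The compounds shown leave open whether the step requires both sulfur atoms, as the entering group differs from the leaving one in more than a single atom. They also leave open where a ring carrying an amine or a chlorine instead would fall in this assay.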